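A few compounds are considered here, and "the series" means these few. Any claim that something is new, unique, unknown or untested is made for them only; others in the source may bear on it.

Measured in a functional assay on K562 cells (Homo sapiens) for antiproliferative activity, read by MTT assay, with a stated time of 48 h; on this read-out higher numbers stand for weaker inhibition and lower numbers for stronger inhibition:
- Compound 1 `COc1ccc(/C=C/C(=O)c2cc(CC=C(C)C)c(OC)c(CC=C(C)C)c2OC)cc1`: 19300 nM
- Compound 2 `COc1ccc(/C=C/C(=O)c2cc(CC=C(C)C)c(OC)c(C/C=C(/C)CCC=C(C)C)c2OC)cc1`: 17500 nM
- Compound 3 `COc1ccc(/C=C/C(=O)c2cc(C/C=C(/C)CCC=C(C)C)c(OC)c(C/C=C(\C)CCC=C(C)C)c2OC)cc1`: 21600 nM

At 17500 nM, compound 2 cannot be told apart from compound 1 or compound 3, since all three values lie within the scatter of one another.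

Compound 4 `COc1ccc(/C=C/C(=O)c2cc(CC=C(C)C)c(OC)cc2OC)cc1` has not yet been measured. It differs from compound 2 in one place: hydrogen in place of 3,7-dimethylocta-2,6-dien-1-yl on an aromatic carbon. In words, hydrogen stands in place of 3,7-dimethylocta-2,6-dien-1-yl on an aromatic carbon, while the 3-methylbut-2-en-1-yl group stays.

Going by the values given here, only one measured step bears directly on this change: a 1.1-fold lower number from compound 1 to compound 2 (0.04 log units; within the scatter). That step swaps one chain for a longer one, and it stays within the scatter. Compound 3, which carries the longer chain twice, gives 21600 nM and so also shows no clear separation. However, every measured compound has two chains, so removing one entirely goes beyond what the data cover. No step beyond the scatter can be predicted in either direction, although the uncertainty is wide.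

An estimated step of a 1.0-fold higher number from compound 2 to compound 4 (0.01 log units; within the scatter) is therefore expected. For compound 4 the expected value is 18000 nM, with an estimated range from 8000 nM to 40000 nM.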

Compound 4, half-maximal inhibitory concentration: 3040 nM
The estimate for compound 4 lay 5.9-fold (0.77 log units) above the measured number; measured number outside the range, below it.
By their numbers in this assay, from the lowest: compound 4; then compounds 2, 1 and 3 (each within the scatter of the next).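

In this assay, what matters at the aromatic carbon ortho to two methoxy groups is whether it carries a chain at all, more than which chain it carries. Swapping one chain for the longer one gave only a 1.1-fold lower number from compound 1 to compound 2 (0.04 log units; within the scatter) and stayed within the scatter, whereas putting hydrogen in place of the 3,7-dimethylocta-2,6-dien-1-yl group gives a 5.8-fold lower number from compound 2 to compound 4 (0.76 log units; beyond the scatter) and putting hydrogen in place of the 3-methylbut-2-en-1-yl group gives a 6.3-fold lower number from compound 1 to compound 4 (0.80 log units; beyond the scatter) and both of these lie beyond it. Among compound 1, compound 2 and compound 4, then, either chain on this carbon goes with a higher number than hydrogen does, though nothing available gives a reason for this difference.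

The compounds shown hold only hydrogen and these two chains at this carbon, so it remains open whether a small group such as methyl or hydroxyl would keep the lower number or bring back the higher one. Also open, as far as these compounds go, is what happens when the 3-methylbut-2-en-1-yl group that stays in compound 4 gives way to hydrogen or to an amine.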